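Changing the amine on the propyl chain of compound 2

This account rests on a few compounds, and the source may have more. Where it says the series, first, only, none or still open, it means among the compounds named here.

Of the compounds shown here, two built on the same core have been measured so far. In a functional assay on HL-60 cells (Homo sapiens) for antiproliferative activity, read by MTT assay, with a stated time of 48 h (on this read-out lower numbers stand for stronger inhibition and higher numbers for weaker inhibition), compound 1 `CN1CCN(CCn2c(N)c(-c3nc4ccccc4[nH]3)c3nc(C#N)c(C#N)nc32)CC1` gives 4300 nM, and compound 2 `CN(C)CCCn1c(N)c(-c2nc3ccccc3[nH]2)c2nc(C#N)c(C#N)nc21` gives 870 nM, the lower of the two numbers and so the stronger inhibition.

The next compound, compound 3 `CN1CCN(CCCn2c(N)c(-c3nc4ccccc4[nH]3)c3nc(C#N)c(C#N)nc32)CC1`, has 4-methylpiperazin-1-yl in place of dimethylamino on a saturated chain carbon, three bonds along the chain from an aromatic nitrogen. Its side chain is thus 3-(4-methylpiperazin-1-yl)propyl.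

Going by the values given here, only one measured step bears on this change: a 4.9-fold lower number from compound 1 to compound 2 (0.69 log units; beyond the scatter). That step is modest but beyond the scatter, and it mixes two differences, since the side chain goes from 2-(4-methylpiperazin-1-yl)ethyl to 3-(dimethylamino)propyl. The data cannot separate the share of the amine from the share of the chain. Compound 3 has the amine of compound 1 and the chain length of compound 2, so a value between the two seems likely.

The step expected in this assay is therefore a 2.3-fold higher number from compound 2 to compound 3 (0.36 log units; beyond the scatter), recovering only part of the earlier gap. The estimate for compound 3 is 2000 nM, with an expected range of 800 nM to 5000 nM.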

Compound 3, half-maximal inhibitory concentration: 750 nM
Beside the measured number, compound 3's estimate is 2.7-fold (0.43 log units) above it, and the stated range ends above it.
By their numbers in this assay, from the lowest: compounds 3 and 2 (each within the scatter of the next); then compound 1.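

In this assay, putting 4-methylpiperazin-1-yl in place of dimethylamino on a saturated chain carbon, three bonds along the chain from an aromatic nitrogen, gives a 1.2-fold lower number from compound 2 to compound 3 (0.06 log units; within the scatter), so on the propyl chain this assay does not tell the ring-bearing amine from the open-chain one. With 4-methylpiperazin-1-yl held the same, changing 2-(4-methylpiperazin-1-yl)ethyl to 3-(4-methylpiperazin-1-yl)propyl gives a 5.7-fold lower number from compound 1 to compound 3 (0.76 log units; beyond the scatter), which isolates the chain and shows that, among these three compounds, the earlier mixed gap tracks chain length rather than the amine. Nothing measured here explains why the propyl chain goes with the lower number.

As far as these compounds go, the amine's share on the shorter chain stays open, and a 2-(dimethylamino)ethyl side chain on the shared core would show whether dimethylamino and 4-methylpiperazin-1-yl also match there. From the compounds shown here alone, it is equally open whether a longer chain, such as 4-(4-methylpiperazin-1-yl)butyl, continues the trend from ethyl to propyl, and whether an amine such as morpholine or pyrrolidine on the propyl chain matches these two.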